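The source may hold more compounds than are shown below. What is called first, only, known or untested is meant among the compounds shown, and "the series" means these compounds.

Working notes on the series, cytotoxicity arm.

Compound 1 `Cc1cc(C)c(Oc2cc(Nc3ccc(C#N)cc3)ncc2C(=O)NCc2cn(Cc3cccc(Cl)c3)nn2)c(C)c1` is the reference for the next step. In an ADME assay on MT4 cells (Homo sapiens) for cytotoxicity, read by MTT assay, with a stated time of 5 days (on this read-out higher numbers stand for lower toxicity in this test and lower numbers for higher toxicity in this test), compound 1 gives 187000 nM, the highest of the three measured numbers, though every neighbour sits within the scatter of it. Compound 3 `Cc1ccc(Cn2cc(CNC(=O)c3cnc(Nc4ccc(C#N)cc4)cc3Oc3c(C)cc(C)cc3C)nn2)cc1` gives 165000 nM in this assay and is the nearest of the two. Compound 2 `Cc1cccc(Cn2cc(CNC(=O)c3cnc(Nc4ccc(C#N)cc4)cc3Oc3c(C)cc(C)cc3C)nn2)c1` gives 114000 nM in this assay and is the furthest. The measured steps are all small: a 1.6-fold lower number from compound 1 to compound 2 (0.21 log units; within the scatter), a 1.1-fold lower number from compound 1 to compound 3 (0.05 log units; within the scatter) and a 1.4-fold higher number from compound 2 to compound 3 (0.16 log units; within the scatter). None of them leaves the scatter, so across these three compounds the read-out in this assay is flat.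

Compound 4 `Cc1cc(C)c(Oc2cc(Nc3ccc(C#N)cc3)ncc2C(=O)NCc2cn(Cc3ccccc3Cl)nn2)c(C)c1` differs from compound 1 as follows: 2-chlorophenyl in place of 3-chlorophenyl on a saturated chain carbon bound to an aromatic nitrogen. Within the data shown here, the steps that bear on this all touch the same saturated chain carbon bound to an aromatic nitrogen, exchanging one substituted benzyl group for another, and each of them stayed within the scatter. No step beyond the scatter is therefore expected in this assay, in either direction. For compound 4 the expected step is a 1.1-fold lower number from compound 1 to compound 4 (0.05 log units; within the scatter). Compound 4 is estimated at 165000 nM in this assay, with a range from 85000 nM to 320000 nM.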

Compound 4, half-maximal cytotoxic concentration: >= 188000 nM
Compound 4: a limit, no number (the forecaster's own chance of this, stated with the estimate: 10%); middle value at least 1.1-fold (0.05 log units) from the limit.
By their numbers in this assay, from the lowest: compounds 2, 3 and 1 (each within the scatter of the next). At a limit, above all of these: compound 4.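

Placing the chloro on 2-chlorophenyl in place of 3-chlorophenyl, on a saturated chain carbon bound to an aromatic nitrogen, gives a limit and not a number for compound 4 in this assay: the limit of >= 188000 nM in this assay, at which 1 of the 4 values shown sits. The size of the step from compound 1 cannot be read, and the other two new steps give only floors within the scatter, an at least 1.1-fold higher number from compound 3 to compound 4 (0.05 log units; that floor lies within the scatter) and an at least 1.6-fold higher number from compound 2 to compound 4 (0.21 log units; that floor lies within the scatter). The same atoms joined differently thus give a number no lower from compound 1 to compound 4 (the limit leaves the size open), extending the flat read-out at this position to a chloro shift.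

From the compounds shown here alone, how far compound 4 truly lies from the other three compounds stays open. Also open, going by these compounds, is the read-out in this assay with a carboxylic acid on the phenyl ring or an amine at this position.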